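Amide Change on a Stable Scaffold

This account rests on a few compounds, and the source may have more. Where it says the series, first, only, none or still open, it means among the compounds named here.

Measured so far:
compound 1, `CNS(=O)(=O)c1ccccc1Nc1cc(-c2ccc3ccn(C)c3c2)c2nccnc2c1`, gives 0.2 h
compound 2, `CN1CCC(NC(=O)c2ccncc2Nc2cc(-c3ccc4ccn(C)c4c3)c3nccnc3c2)CC1`, gives > 1 h

In an ADME assay on microsomes from liver (Mus musculus, strain CD-1) for metabolic stability, read by LC-MS, tested at 2 uM (a lower number here means that the compound disappears faster, a higher number that the compound lasts longer), compound 1 is cleared quickly, with a half-life of 0.2 h. Compound 2 behaves differently: its value of > 1 h is a limit of the assay and not a number. Compound 2 thus stands at the limit of > 1 h in this assay, at which 1 of the 2 values shown sits. Compound 3, `CN1CCC(N(C)C(=O)c2ccncc2Nc2cc(-c3ccc4ccn(C)c4c3)c3nccnc3c2)C1`, has not yet been measured. It differs from compound 2 in one place, on the carbonyl carbon whose other neighbour is an aromatic carbon: methyl(1-methylpyrrolidin-3-yl)amino in place of (1-methylpiperidin-4-yl)amino on a carbonyl carbon. For the measured compounds named here, no step between two measured compounds is available, and the one complete value belongs to compound 1, which differs from both in other places. The expected step in this assay, a step that the limit leaves unreadable from compound 2 to compound 3, is therefore taken as small, within the usual scatter, with no clear direction. Compound 3 is expected to show a half-life of about 1.2 h, estimated between 0.5 h and 3 h.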

Compound 3, half-life: > 1 h
Compound 3 gave a limit, no number; the forecaster's own chance of this, stated with the estimate: 55%; the middle value lies beyond the limit too.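

In this assay compound 3 gives > 1 h, a limit and not a number. Compound 2 also gives a limit, so no step between compound 2 and compound 3 can be read: the limit of > 1 h in this assay, at which 2 of the 3 values shown sit.

From the compounds shown here alone, how long either compound actually lasts, and whether methyl(1-methylpyrrolidin-3-yl)amino in place of (1-methylpiperidin-4-yl)amino changes that, stays open.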